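A few compounds are considered here, and "the series" means these few. Any claim that something is new, unique, unknown or untested is made for them only; others in the source may bear on it.

Measured compounds
compound 1, `O=C(NC[C@]1(CC2CC2)[C@@H]2CN(S(=O)(=O)c3ccccc3F)C[C@@H]21)c1ccc(Cl)cc1Cl` — > 10000 nM
compound 2, `Cn1cnc(S(=O)(=O)N2C[C@@H]3[C@H](C2)[C@@]3(CNC(=O)c2ccccc2Cl)CC2CC2)c1` — 19 nM

In an assay on isolated protein for inhibition of sodium- and chloride-dependent glycine transporter 1 (Homo sapiens) (a higher number here means a weaker inhibitor, a lower number a stronger inhibitor), compound 1 gives > 10000 nM, which is a limit of the assay and not a number. In this assay compound 2 gives 19 nM, the only actual number shown in the series. The other value shown, that of compound 1, sits at the limit described in the limit of > 10000 nM in this assay, at which 1 of the 2 values shown sits. Compound 3, `Cn1cnc(S(=O)(=O)N2C[C@@H]3[C@H](C2)[C@@]3(CNC(=O)c2c(Cl)cccc2Cl)CC2CC2)c1`, differs from compound 2 by chloro in place of hydrogen on an aromatic carbon, ortho to a large group and meta to a chloro group: 2-chlorophenyl becomes 2,6-dichlorophenyl. No measured step between two compounds is shown, so the size of the step from compound 2 to compound 3 in this assay rests on the structural change alone; a modest shift is expected, possibly not beyond the scatter, with weaker inhibition somewhat more likely than stronger. For compound 3 the expected value in this assay is 40 nM, within 10 nM to 200 nM, corresponding to an expected step of a 2.1-fold higher number from compound 2 to compound 3 (0.32 log units; beyond the scatter).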

Compound 3, half-maximal inhibitory concentration: 28 nM
The estimate for compound 3 lay 1.4-fold (0.15 log units) above the measured number; low and high end bracket the measured number.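

Among the compounds shown here, replacing 2-chlorophenyl with 2,6-dichlorophenyl in this assay gives a 1.5-fold higher number from compound 2 to compound 3 (0.17 log units; within the scatter), the first single-change comparison. This aromatic carbon, ortho to a large group and meta to a chloro group, therefore accepts a chloro in place of hydrogen with no shift that can be told from the scatter, and the two compounds cannot be ordered in this assay. Nothing measured among the compounds shown bears on a cause for this result.

A single substitution at this position says little about what a methoxy group, an amine or a carboxylic acid would do on the same carbon. On these data alone, the effect of removing both chloro groups to leave an unsubstituted phenyl also remains open.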